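This account rests on a few compounds, and the source may have more. Where it says the series, first, only, none or still open, it means among the compounds named here.

The measured compounds and their values in a functional assay for agonist activity at Free fatty acid receptor 1 (Homo sapiens), read by FLIPR, in the presence of a further agent that is not named here; a higher number here means that more compound is needed for the effect, a lower number that less compound is needed:

Compound 1, `O=C1NC(=O)C(Cc2ccc(Oc3ccccc3)cc2)S1`: 307 nM
Compound 2, `Cc1ccnc(Oc2ccc(CC3SC(=O)NC3=O)cc2)c1`: 4280 nM
Compound 3, `Cc1ccc(Oc2ccc(CC3SC(=O)NC3=O)cc2)cc1`: 547 nM

Among these three, compound 1 gives the lowest number. Compound 3 sits close to it, since the step of a 1.8-fold higher number from compound 1 to compound 3 (0.25 log units; within the scatter) stays within the scatter. Compound 2 stands apart: the step of a 14-fold higher number from compound 1 to compound 2 (1.14 log units; beyond the scatter) is large, and going back the other way, the step of a 7.8-fold lower number from compound 2 to compound 3 (0.89 log units; beyond the scatter) is modest but clear.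

Compound 4, `O=C1NC(=O)C(Cc2ccc(-c3ccccc3)cc2)S1`, has not yet been measured. It differs from compound 1 in one place: phenyl in place of phenoxy on an aromatic carbon. The two rings of compound 1 are kept, but the oxygen between them is gone. Among the measured compounds shown here, none of the measured steps bears directly on this: the steps from compound 1 to compound 2 and from compound 2 to compound 3 exchange the ring that sits on the oxygen, and the step from compound 1 to compound 3 adds a methyl, while no measured pair shows what removing the oxygen does. What can be said is that compound 1, with a plain phenyl on the oxygen, gives the lowest number, 307 nM, and compound 4 keeps that plain phenyl. The estimate for compound 4 in this assay is therefore a number close to that of compound 1, with a step of a 1.5-fold higher number from compound 1 to compound 4 (0.17 log units; within the scatter) expected and wide uncertainty in either direction, giving an expected value of 450 nM within a range from 120 nM to 1800 nM.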

Compound 4, half-maximal effective concentration: 2220 nM
For compound 4 the middle estimate is 4.9-fold (0.69 log units) below the measured one; measured number outside the range, above it.
By their numbers in this assay, from the lowest: compounds 1 and 3 (each within the scatter of the next); then compounds 4 and 2 (each within the scatter of the next).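

Replacing phenoxy with phenyl gives a 7.2-fold higher number from compound 1 to compound 4 (0.86 log units; beyond the scatter) in this assay, so keeping the plain outer ring is not enough to hold the number near that of compound 1. Among the compounds shown here, the earlier steps all kept the oxygen and changed only the ring on it or added a methyl, so this is the first sign that the oxygen of the phenoxy group itself counts at this position on the aromatic ring. No measurement is available that would explain the shift, so the data record its size and not its origin.

From the compounds shown here alone, it remains open whether the oxygen atom matters in its own right or whether any single-atom link would serve, which a methylene, an amine nitrogen or a sulfur atom in its place could help to separate. Also open, going by these compounds, is whether a methyl on the outer ring, which gave a 1.8-fold higher number from compound 1 to compound 3 (0.25 log units; within the scatter) with the oxygen present, would have an equally small effect on the directly joined rings of compound 4.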